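Removing One Methoxy Group on Two Related Cores

The source may hold more compounds than are shown below. What is called first, only, known or untested is meant among the compounds shown, and "the series" means these compounds.

Compound 1 `COc1cc(/C=N/N(C)c2nc3ccccc3s2)cc(OC)c1O` gives 3% in a physicochemical assay on cells (Homo sapiens), with a stated time of 18 h, tested at 10 uM; a higher number here means a weaker effect of the compound at the concentration tested, a lower number a stronger effect. Compound 3 `COc1cc(/C=N/N(C)c2nc3ccccc3s2)ccc1O` differs from compound 1 by hydrogen in place of methoxy on an aromatic carbon, and in this assay compound 3 gives 9%; the step is a number 6 percentage points higher from compound 1 to compound 3 (within the scatter). Compound 2 `COc1cc(/C=N/N2C(=O)CSC2=S)cc(OC)c1O` gives 5% in this assay; the difference between the cores of compound 1 and compound 2 is not broken down here. Compound 4 `COc1cc(/C=N/N2C(=O)CSC2=S)ccc1O` differs from compound 2 by hydrogen in place of methoxy on an aromatic carbon, the same kind of change as from compound 1 to compound 3, though the surroundings are not identical: in compound 4 the place is meta to a group of 9 heavy atoms, whereas in compound 3 it is meta to a large group. For compound 4 a step of a number 5 percentage points higher from compound 2 to compound 4 (within the scatter) is expected, resting on the step of a number 6 percentage points higher from compound 1 to compound 3 (within the scatter). Compound 4 is therefore estimated at 10%, between 2% and 25%, in this assay.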

Compound 4, a percentage reported as activity, at one concentration (the size of the read-out at that concentration, not a potency): 5%
Compound 4: the middle estimate sits 5 percentage points above what was measured; the range from low to high includes it.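

In this assay, taking away the methoxy group gives no change at the digits printed from compound 2 to compound 4 (within the scatter), and on the other core the same change gives a number 6 percentage points higher from compound 1 to compound 3 (within the scatter), so on neither core does this change produce a step beyond the scatter. This shows that the two cores agree for this one change, but with both steps within the scatter it cannot show that the change carries over with any real size, or that its effect is the same on other cores. Nothing measured here bears on why the change makes so little difference.

The compounds shown leave open what an amine or a carboxylic acid would give in that place on the ring. Going by these compounds, all four compounds also keep the hydroxy group, so what a longer chain such as ethoxy would give there remains open too.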